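The source may hold more compounds than are shown below. What is called first, only, known or untested is meant among the compounds shown, and "the series" means these compounds.

Two compounds of this series have a reading in an assay on isolated protein with Polyunsaturated fatty acid 5-lipoxygenase (Homo sapiens) as the target; a lower number here means a stronger inhibitor, a higher number a weaker inhibitor. Compound 1 `Cn1nnc(-c2cc(-c3ccccc3)c3ccc(OCc4cccc(C5(O)CCOCC5)c4)cc3c2)n1` gives 120 nM in this assay, and compound 2 `OC1(c2cccc(COc3ccc4c(-c5ccoc5)cc(C5=NCCO5)cc4c3)c2)CCOCC1` gives 70 nM. Compound 2 holds the smaller of the two numbers, but the gap to compound 1 falls within the usual scatter of this assay, so the two readings cannot be told apart on potency and no trend can be drawn from them.

The next member, compound 3 `OC1(c2cccc(COc3ccc4c(-c5ccoc5)cc(Cc5nccs5)cc4c3)c2)CCOCC1`, differs from compound 2 in one place: a group of 6 heavy atoms (4 carbon, 1 nitrogen, 1 sulfur; one five-membered aromatic ring with 2 hetero atoms) in place of a group of 5 heavy atoms (3 carbon, 1 nitrogen, 1 oxygen; one five-membered non-aromatic ring with 2 hetero atoms), on an aromatic carbon. Among the measured compounds shown here, no pair of measured compounds isolates a change of this kind, so there is no measured step to lean on; the two readings available only show that the related group in compound 1 and the group leaving compound 2 sit within the scatter of each other. The expected step from compound 2 to compound 3 in this assay is accordingly small, if anything toward a weaker inhibitor, and likely not beyond the scatter, i.e. a 1.6-fold higher number from compound 2 to compound 3 (0.20 log units; within the scatter). For compound 3 the estimated reading in this assay is 110 nM, expected to fall between 35 nM and 400 nM.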

Compound 3, half-maximal inhibitory concentration: 140 nM
Compound 3: middle estimate off by 1.3-fold (0.10 log units), on the low side; low and high end bracket the measured number.
By their numbers in this assay, from the lowest: compounds 2, 1 and 3 (each within the scatter of the next).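

In this assay, replacing the five-membered non-aromatic ring of compound 2 with (1,3-thiazol-2-yl)methyl on this aromatic carbon gives a 2.0-fold higher number from compound 2 to compound 3 (0.30 log units; within the scatter), the first step measured at this position in the series. The position, meta to the furan-3-yl group, therefore tolerates a group of 6 heavy atoms carrying a five-membered aromatic ring with sulfur, without a double bond outside aromatic rings, and the two readings cannot be told apart on potency. No supporting measurement bears on this step, so the result stands as an observation only.

From the compounds shown here alone, both groups compared here carry no net charge and have the same counts of hydrogen-bond donors and acceptors, so it remains open how this position responds to an amine, a carboxylic acid, or something as small as a methoxy group. Going by these compounds, it is also open whether the same replacement gives a step of similar size when the furan-3-yl group is exchanged for the phenyl group found in compound 1.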